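The source may report more compounds than this note shows. Statements on the series, on what has been measured and on what is new or still open speak of the compounds shown alone.

Measured so far in a functional assay on A549 cells (Homo sapiens) for cytotoxicity, read by MTT assay, with a stated time of 72 h; on this read-out higher numbers stand for weaker inhibition and lower numbers for stronger inhibition:
- compound 1 `O=C1c2c[n+]([O-])c3ccccc3c2C(=O)c2c1c1ccccc1n2Cc1cn([C@H]2O[C@H](CO)[C@@H](O)[C@H]2O)nn1`: 2680 nM
- compound 2 `O=C1c2c[n+]([O-])c3ccccc3c2C(=O)c2c1c1ccccc1n2CCN1CCCC1`: 410 nM

Of these two, compound 2 carries the lower number at 410 nM, which means the stronger inhibition. Compound 1 stands higher at 2680 nM, and that gap lies beyond the usual scatter.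

Next in line, not yet measured, is compound 3 `CN1CCN(CCCCCCn2c3c(c4ccccc42)C(=O)c2c[n+]([O-])c4ccccc4c2C3=O)CC1`. Relative to compound 2 the change is 4-(4-methylpiperazin-1-yl)butyl in place of pyrrolidin-1-yl on a saturated chain carbon, two bonds along the chain from an aromatic nitrogen. It sits on a saturated chain carbon, two bonds along the chain from an aromatic nitrogen. Cut one bond further out, the same difference reads (pyrrolidin-1-yl)methyl to 5-(4-methylpiperazin-1-yl)pentyl.

Among the measured compounds shown here, no measured pair isolates a change of this kind, so the shared core and the value of compound 2 at 410 nM are the only anchors. No step beyond the scatter is expected in this assay, in either direction. The expected move is a 1.2-fold lower number from compound 2 to compound 3 (0.07 log units; within the scatter), which is a small one. For compound 3 the estimate is 350 nM, with an expected range of 120 nM to 1100 nM.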

Compound 3, half-maximal inhibitory concentration: 330 nM
Estimate against measurement, compound 3: 1.1-fold (0.03 log units) above; the range from low to high includes it.
By their numbers in this assay, from the lowest: compounds 3 and 2 (each within the scatter of the next); then compound 1.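

In this assay, among the compounds shown here, the first pair that isolates a change at this place, on a saturated chain carbon, two bonds along the chain from an aromatic nitrogen, gives a 1.2-fold lower number from compound 2 to compound 3 (0.09 log units; within the scatter) for 4-(4-methylpiperazin-1-yl)butyl in place of pyrrolidin-1-yl. The position therefore accepts a group of 11 heavy atoms in place of one of 5, and a six-membered ring with 2 hetero atoms in place of a five-membered ring with 1, with no step beyond the scatter in this read-out. Nothing measured on these compounds accounts for this result.

The step alters the length of the chain and the ring at its end together, so the share of each stays unresolved: a butyl chain ending in pyrrolidin-1-yl, or the 4-methylpiperazin-1-yl ring on the shorter chain of compound 2, would separate the two. Other end groups, such as morpholine, an open dimethylamino group or a carboxylic acid, also lie outside the compounds shown, so how far this tolerance extends remains open.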